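Ethoxy for isobutylamino on the carbonyl: compound 4

A few compounds are considered here, and "the series" means these few. Any claim that something is new, unique, unknown or untested is made for them only; others in the source may bear on it.

Among the compounds with values here, compound 3 `CCCSc1nc(Cl)c2c(n1)N(Cc1ccccc1)C(C(=O)NCC(C)C)N2` gives 48200 nM in a functional assay on A549 cells (Homo sapiens) for antiproliferative activity, read by MTT assay, with a stated time of 72 h (on this read-out higher numbers stand for weaker inhibition and lower numbers for stronger inhibition), the second highest of the three numbers measured so far. Compound 1 `CCCSc1nc(Cl)c2c(n1)N(Cc1ccccc1)C(C(=O)O)N2`, with hydroxy on the carbonyl carbon, gives 10700 nM, and compound 2 `CCCSc1nc(Cl)c2c(n1)N(Cc1ccccc1)C(C(=O)NCCNC(=O)OC(C)(C)C)N2` gives 53200 nM. The step of a 4.5-fold higher number from compound 1 to compound 3 (0.65 log units; beyond the scatter) and the step of a 5.0-fold higher number from compound 1 to compound 2 (0.70 log units; beyond the scatter) run the same way, while a 1.1-fold lower number from compound 2 to compound 3 (0.04 log units; within the scatter) shows the two amides sitting together.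

Compound 4 `CCCSc1nc(Cl)c2c(n1)N(Cc1ccccc1)C(C(=O)OCC)N2` carries the change (ethoxy in place of isobutylamino on a carbonyl carbon); cut one bond further out, this reads isobutylcarbamoyl to ethoxycarbonyl. Within the data shown here, no measured step exchanges an amide for an ester, so the bearing steps are the two acid-to-amide pairs, both modest and beyond the scatter, and the amide-to-amide pair within it. Among the measured compounds shown here, the ester has no direct precedent among the measured compounds; its expected position lies between compound 1 and the amides, closer to the amides. The step from compound 3 to compound 4 is estimated as a 1.9-fold lower number from compound 3 to compound 4 (0.29 log units; within the scatter). Compound 4 is estimated at 25000 nM, with a range from 8000 nM to 80000 nM.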

Compound 4, half-maximal inhibitory concentration: 13800 nM
Compound 4: middle estimate off by 1.8-fold (0.26 log units), on the high side; measured number inside the range.
By their numbers in this assay, from the lowest: compounds 1 and 4 (each within the scatter of the next); then compounds 3 and 2 (each within the scatter of the next).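

In this assay the ester separates from both amides, with a 3.5-fold lower number from compound 3 to compound 4 (0.54 log units; beyond the scatter) and a 3.9-fold lower number from compound 2 to compound 4 (0.59 log units; beyond the scatter) both modest and beyond the scatter. Against the acid the picture differs: a 1.3-fold higher number from compound 1 to compound 4 (0.11 log units; within the scatter) is within the scatter, so ethyl in place of hydrogen leaves compound 1 and compound 4 together. The earlier compounds shown here could not show whether the gap between the acid and the amides belonged to the free acid itself; across these four compounds, the split instead falls between the two amides and the two compounds without an amide, and none goes against it.

Still open, as far as these compounds go, is whether a tertiary amide, lacking the amide hydrogen, would sit with the amides or with compound 1 and compound 4, and whether a longer chain on the ester oxygen, such as butoxy, would stay with compound 4. No measurement available here accounts for the split.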